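The source may hold more compounds than are shown below. What is called first, only, known or untested is meant among the compounds shown, and "the series" means these compounds.

In an assay for inhibition of acyl-CoA:cholesterol acyltransferase (Oryctolagus cuniculus), using microsomes (a lower number here means a stronger inhibitor, a higher number a weaker inhibitor), compound 1 `CCCCCCCCCCCCCCCC(=O)Nc1cccc2c1OC(C)(C)C2` gives 890 nM, compound 2 `CCCCCCCCC(C)(C)C(=O)Nc1c(C)cc(C)c2c1OC(C)(C)C2` gives 140 nM, and compound 3 `Cc1cc(C)c(NC(=O)C(C)(C)CCCCc2ccccc2)c2c1CC(C)(C)O2` gives 210 nM. Compound 3 thus sits together with compound 2, the two within the scatter of each other, while compound 1 lies apart from both with a higher number beyond the scatter. Compound 4 `Cc1cc(C)c(NC(=O)C(C)(C)CCCCCCc2ccccc2)c2c1CC(C)(C)O2` carries phenethyl in place of phenyl on a saturated chain carbon, five bonds along the chain from a carbonyl carbon. Among the measured compounds shown here, the one measured step of related kind, a 1.5-fold higher number from compound 2 to compound 3 (0.18 log units; within the scatter), altered the same chain carbon and stayed within the scatter. Compound 1 and compound 2 differ in several places, so their values say little here. No step beyond the scatter is therefore expected in this assay. Compound 4 is expected to give about 200 nM, between 70 nM and 600 nM, an expected step of a 1.1-fold lower number from compound 3 to compound 4 (0.02 log units; within the scatter).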

Compound 4, half-maximal inhibitory concentration: 81 nM
Compound 4: the middle estimate sits 2.5-fold (0.39 log units) above what was measured, within the range that was stated.
By their numbers in this assay, from the lowest: compounds 4, 2 and 3 (each within the scatter of the next, the first and the last beyond it); then compound 1.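

In this assay, phenethyl in place of phenyl at this saturated chain carbon gives a step beyond the scatter (a 2.6-fold lower number from compound 3 to compound 4 (0.41 log units; beyond the scatter)), whereas the earlier change on this chain stayed within it, so the position does respond to the length of the phenyl-bearing chain. Compared with the all-alkyl chain, however, the longer phenyl-bearing chain stays within the scatter (a 1.7-fold lower number from compound 2 to compound 4 (0.24 log units; within the scatter)). Nothing available explains the step. Going by these compounds, whether 4-phenylbutyl would extend the change remains open, as does the effect of an amine or a carboxylic acid at the chain end.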